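A few compounds are considered here, and "the series" means these few. Any claim that something is new, unique, unknown or untested is made for them only; others in the source may bear on it.

Among the compounds with values here, compound 2 `CN(C)c1ccc2c(Oc3ccc(NC(=O)NCc4ccc(F)cc4)cc3)ncnc2c1` is one of two compounds measured in an ADME assay on the whole organism (Rattus norvegicus, strain Sprague-Dawley) for pharmacokinetics, read by LC-MS, with a stated time of 24 h, at a dose of 5 mg/kg by the intravenous route; a lower number here means slower removal, a higher number faster removal of the compound. In this assay compound 2 gives 12.2 mL/min/kg, the higher of the two numbers. Within the data shown here, its only neighbour, compound 1 `Cc1ccc(CNC(=O)Nc2ccc(Oc3ncnc4cc(N(C)C)ccc34)cc2)cn1`, gives 5.6 mL/min/kg in this assay, and the step of a 2.2-fold higher number from compound 1 to compound 2 (0.34 log units; beyond the scatter) is the one measured step so far.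

The next compound, compound 3 `COc1ccc(CNC(=O)Nc2ccc(Oc3ncnc4cc(N(C)C)ccc34)cc2)cc1`, differs from compound 2 in one place: methoxy in place of fluoro on an aromatic carbon. Among the measured compounds shown here, no measured step covers this particular exchange. For the measured compounds named here, the only step on record, a 2.2-fold higher number from compound 1 to compound 2 (0.34 log units; beyond the scatter), replaced the whole aromatic ring at that end of the molecule rather than a single group on it, and it was modest in size. Since the change from compound 2 to compound 3 is smaller in scope than that one, the step of a 1.1-fold higher number from compound 2 to compound 3 (0.03 log units; within the scatter) is expected to stay within the scatter of repeated measurements, with no clear direction. Compound 3 is therefore estimated to give about 13 mL/min/kg in this assay, within a range of 6 mL/min/kg to 28 mL/min/kg.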

Compound 3, clearance: 16.5 mL/min/kg
Compound 3: middle estimate off by 1.3-fold (0.10 log units), on the low side; measured number inside the range.
By their numbers in this assay, from the lowest: compound 1; then compounds 2 and 3 (each within the scatter of the next).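

On the aromatic carbon para to a large group, the exchange of fluoro for methoxy adds one heavy atom and one hydrogen-bond acceptor, yet in this assay the result is a 1.4-fold higher number from compound 2 to compound 3 (0.13 log units; within the scatter) and fluoro and methoxy cannot be told apart at this position. Within the data shown here, the second new step, a 2.9-fold higher number from compound 1 to compound 3 (0.47 log units; beyond the scatter) with 4-methoxyphenyl in place of 6-methylpyridin-3-yl, lies beyond the scatter, so compound 3 joins compound 2 in showing a clear difference from compound 1 when that ring is exchanged, and the ring exchange has so far moved the number more clearly than the single group on the ring. Nothing available here gives a reason for these differences in how fast the compounds are removed.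

Going by these compounds, only fluoro and methoxy have been compared at this position, so it remains open whether a carboxylic acid, an amine or a longer ether such as ethoxy would move the number beyond the scatter. On these data alone, it is also open whether the ring nitrogen or the methyl group of 6-methylpyridin-3-yl matters more, which a plain pyridin-3-yl ring could help to separate.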